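This account rests on a few compounds, and the source may have more. Where it says the series, first, only, none or still open, it means among the compounds named here.

Measured so far:
compound 1, `CS/C(=N\C(=O)c1ccno1)NC(=O)c1ccno1` — > 100000 nM
compound 2, `CS/C(=N\C(=O)c1cc2ccccc2s1)NC(=O)c1cc2ccccc2s1` — 53000 nM
compound 3, `C[Se]/C(=N\C(=O)c1cccs1)NC(=O)c1cccs1` — 1500 nM

In a functional assay on HepG2 cells (Homo sapiens) for cytotoxicity, read by MTT assay, with a stated time of 72 h (on this read-out higher numbers stand for weaker inhibition of growth and lower numbers for stronger inhibition of growth), compound 1 gives > 100000 nM, which is a limit of the assay rather than a number, as noted in the limit of > 100000 nM in this assay, at which 1 of the 3 values shown sits. Compound 2 gives 53000 nM in this assay. Compound 3 gives 1500 nM in this assay and therefore holds the lowest of the two numbers; its gap to compound 2 lies beyond the scatter, so compound 3 inhibits growth more strongly than compound 2 on these figures.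

Compound 4, `O=C(/N=C(/NC(=O)c1cccs1)[Se]Cc1ccccc1)c1cccs1`, has not been measured. It differs from compound 3 by phenyl in place of hydrogen on a saturated chain carbon bound to a selenium atom, so the whole series keeps the same core and the change sits only on the group bound to selenium. No measured step of this kind exists among these compounds, so the size and direction of the change are open; a modest shift in either direction, or none beyond the scatter, is expected. Compound 4 is estimated at 2000 nM, within 500 nM to 8000 nM, which means an expected step of a 1.3-fold higher number from compound 3 to compound 4 (0.12 log units; within the scatter).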

Compound 4, concentration for total growth inhibition: 58100 nM
Compound 4: middle estimate off by 29-fold (1.46 log units), on the low side, outside the stated range (above it).
By their numbers in this assay, from the lowest: compound 3; then compounds 2 and 4 (each within the scatter of the next). At a limit, above all of these: compound 1.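

In this assay, the change from methyl to benzyl on selenium gives a 39-fold higher number from compound 3 to compound 4 (1.59 log units; beyond the scatter). Among the compounds shown here, this is the first step measured at a single place in these compounds, and it shows that the group bound to selenium is not a silent position: adding one phenyl on the saturated chain carbon bound to the selenium atom costs much of the growth inhibition seen with the methyl group. Nothing measured here accounts for the size of this step.

The two compounds at this position leave open whether the loss grows steadily with size or comes from the aromatic ring itself, which an ethyl group or a longer chain on selenium could test. They also leave open whether an amine or a carboxylic acid on the phenyl ring would change the value of the benzyl compound.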